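Swapping bromo for nitro on the hydrazone tail

The source may hold more compounds than are shown below. What is called first, only, known or untested is meant among the compounds shown, and "the series" means these compounds.

Measured compounds:
compound 1 `Cc1ccc(C(=O)NNC(=O)Cn2c(=O)c(Cc3ccccc3)nc3ccccc32)cc1` — 52 nM
compound 2 `O=C(Cn1c(=O)c(Cc2ccccc2)nc2ccccc21)N/N=C/c1ccc(Br)cc1` — 22 nM

In an assay for inhibition of Amine oxidase [flavin-containing] A (Bos taurus), read by fluorescence, with a stated time of 60 min (on this read-out lower numbers stand for stronger inhibition and higher numbers for weaker inhibition), compound 2 gives 22 nM, the lowest of the two numbers shown, with the nearest neighbour, compound 1, at 52 nM. Compound 3 `O=C(Cn1c(=O)c(Cc2ccccc2)nc2ccccc21)N/N=C/c1ccc([N+](=O)[O-])cc1` differs from compound 2 by nitro in place of bromo on an aromatic carbon. For the measured compounds named here, the only measured step, a 2.4-fold lower number from compound 1 to compound 2 (0.37 log units; beyond the scatter), altered a different part of the shared core, so no measured step bears on this exchange. With nothing to point either way, compound 3 is expected to stay within the scatter, a 1.1-fold higher number from compound 2 to compound 3 (0.06 log units; within the scatter). The estimate for compound 3 is 25 nM, in the range 8 nM to 80 nM.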

Compound 3, half-maximal inhibitory concentration: 98 nM
The estimate for compound 3 lay 3.9-fold (0.59 log units) below the measured number; the whole stated range lies below it.
By their numbers in this assay, from the lowest: compound 2; then compounds 1 and 3 (each within the scatter of the next).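

On this tail, the group on the aromatic ring matters: nitro in place of bromo gives a 4.5-fold higher number from compound 2 to compound 3 (0.65 log units; beyond the scatter) and so shows that this position is not indifferent to what it carries. With nitro on it, the hydrazone tail no longer stands apart from the tail of compound 1, as a 1.9-fold higher number from compound 1 to compound 3 (0.28 log units; within the scatter) makes plain. No measurement shown here explains the loss.

Two groups at one position give no trend. Going by these compounds, whether an amine, a methoxy group or chloro at that place would side with bromo or with nitro remains open.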